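A Triazole Substituent Swap in a Weak Cell Inhibitor

The source may report more compounds than this note shows. Statements on the series, on what has been measured and on what is new or still open speak of the compounds shown alone.

Within the data shown here, compound 1 `CCOC(=O)C1=Cc2ccccc2OC1(OCc1cn(CC(=O)Nc2ccc(C)cc2)nn1)C(F)(F)F` holds the only numeric value here: in a functional assay on A549 cells (Homo sapiens) for inhibition, read by MTT assay, with a stated time of 24 h (a lower number here means a stronger inhibitor, a higher number a weaker inhibitor), compound 1 gives 54300 nM. Compound 2 `CCOC(=O)C1=Cc2ccccc2OC1(OCc1cc(-c2ccc([N+](=O)[O-])cc2)no1)C(F)(F)F` gives in this assay only a limit, > 150000 nM. Of the two values shown, compound 2 accounts for (the limit of > 150000 nM in this assay, at which 1 of the 2 values shown sits). Compound 3 `CCOC(=O)C1=Cc2ccccc2OC1(OCc1cn(-c2ccc(F)c(Cl)c2)nn1)C(F)(F)F` has not been measured; it differs from compound 1 by 3-chloro-4-fluorophenyl in place of ((4-methylphenyl)carbamoyl)methyl on an aromatic nitrogen, in words 3-chloro-4-fluorophenyl in place of ((4-methylphenyl)carbamoyl)methyl on an aromatic nitrogen. Among the measured compounds shown here, no measured pair shows the effect of such a change, so the expected step is a 1.3-fold higher number from compound 1 to compound 3 (0.11 log units; within the scatter), probably no larger than the scatter. Compound 3 is therefore estimated at 70000 nM, between 25000 nM and 200000 nM.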

Compound 3, half-maximal inhibitory concentration: 26300 nM
Beside the measured number, compound 3's estimate is 2.7-fold (0.43 log units) above it; the range from low to high includes it.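

In this assay, the aromatic nitrogen of the five-membered ring accepts a very different group, with a 2.1-fold lower number from compound 1 to compound 3 (0.31 log units; beyond the scatter). This single step shows that ((4-methylphenyl)carbamoyl)methyl, with its hydrogen-bond donor, is not needed at this position for the activity seen, as 3-chloro-4-fluorophenyl has no such donor. Nothing shown gives a reason for the step.

On these data alone, whether the chlorine, the fluorine or the loss of the amide matters most stays open. Also open, as far as these compounds go, is how a plain phenyl, a primary amine or a carboxylic acid would compare at this nitrogen.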